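Replacing the Oxolane Amide of a Weak Modulator

This account rests on a few compounds, and the source may have more. Where it says the series, first, only, none or still open, it means among the compounds named here.

compound 1, `O=C(C1CCCO1)N1CC(c2nc(-c3cccc(Cl)c3)no2)C1`: 890 nM
compound 2, `Cc1cccc(-c2noc(C3CN(C(=O)C4CCC(C(F)(F)F)CC4)C3)n2)c1`: > 10000 nM, a limit of the assay
compound 3, `O=C(C1CCC(C(F)(F)F)CC1)N1CC(c2nc(-c3cccc(Cl)c3)no2)C1`: > 10000 nM, a limit of the assay

Among the compounds with values here, in an assay on HEK293 cells for negative allosteric modulation of metabotropic glutamate receptor 5 (Homo sapiens), read by FLIPR (on this read-out lower numbers stand for stronger inhibition and higher numbers for weaker inhibition), compound 1 gives 890 nM, the only number among the three results. Compound 2 sits at the limit of > 10000 nM in this assay, at which 2 of the 3 values shown sit. Compound 3 sits at the same limit, so the step that the two limits leave unreadable from compound 2 to compound 3 cannot be read. Within the data shown here, compound 1 and compound 3 share the chloro-substituted part and differ only at the carbonyl carbon, but no step between them can be sized either, since one of the two is a limit.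

Compound 4, `CC1CCN(C(=O)N2CC(c3nc(-c4cccc(Cl)c4)no3)C2)CC1`, differs from compound 1 by 4-methylpiperidin-1-yl in place of oxolan-2-yl on a carbonyl carbon. Among the measured compounds shown here, no measured step touches this position, so the expectation rests on compound 1 alone. Compound 4 is expected to give 2000 nM in this assay, within 500 nM to 8000 nM, which is an expected step of a 2.2-fold higher number from compound 1 to compound 4 (0.35 log units; beyond the scatter), with a real chance that only a limit is reported.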

Compound 4, half-maximal inhibitory concentration: > 10000 nM
Compound 4 was reported as a limit; the forecaster's own chance of this, stated with the estimate: 30%; middle value at least 5.0-fold (0.69 log units) from the limit.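

In this assay, within the data shown here, 4-methylpiperidin-1-yl in place of oxolan-2-yl on a carbonyl carbon brings an at least 11-fold higher number from compound 1 to compound 4 (1.05 log units; beyond the scatter), the first step at this position that can be sized, and it shows that the read-out depends strongly on the group placed here. This single change alters the ring size, the ring hetero atom and the methyl group together, and the result cannot separate them. Compound 4 itself is a limit of the assay, so the true size of the loss stays unknown, and it joins the other limit values: the limit of > 10000 nM in this assay, at which 3 of the 4 values shown sit.

Steps between the limit values cannot be read, and among the compounds shown only oxolan-2-yl on this carbonyl carbon gives a number. From the compounds shown here alone, whether morpholin-4-yl or oxolan-3-yl here would keep a measurable value remains open.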